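Working notes on compound 4 before its value is known

The source may report more compounds than this note shows. Statements on the series, on what has been measured and on what is new or still open speak of the compounds shown alone.

In a functional assay on MDA-MB-231 cells (Homo sapiens) for inhibition, read by CCK-8 assay, with a stated time of 48 h (on this read-out lower numbers stand for stronger inhibition of growth and higher numbers for weaker inhibition of growth), compound 1 `Cc1ccccc1Nc1nc(Nc2ccccc2)ncc1Cl` gives > 100000 nM, a limit of the assay rather than a number.
In this assay compound 2 `Cc1ccc(Nc2ncc(Cl)c(Nc3ccccc3C)n2)cc1` gives > 100000 nM, again a limit of the assay.
In this assay compound 3 `Cc1ccccc1Nc1nc(Nc2cc(Cl)ccn2)ncc1Cl` gives 52400 nM.

Compound 2 therefore has no number of its own in this assay, only the limit; two of the three values shown sit at that same limit, (the limit of > 100000 nM in this assay, at which 2 of the 3 values shown sit). The step from compound 1 to compound 2 is a step that the two limits leave unreadable from compound 1 to compound 2, so the methyl on the aromatic carbon cannot be judged.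

Compound 4 `Cc1ccccc1Nc1nc(NCc2ccncc2)ncc1Cl` is obtained from compound 2 by the change ((pyridin-4-yl)methyl in place of 4-methylphenyl on a nitrogen on an aromatic ring). The measured steps that touch the same nitrogen are an at least 1.9-fold lower number from compound 2 to compound 3 (0.28 log units; that floor lies within the scatter) and, from the unmethylated partner, an at least 1.9-fold lower number from compound 1 to compound 3 (0.28 log units; that floor lies within the scatter); both are floors that lie within the scatter, and neither involves a benzylic group or a pyridin-4-yl ring. Among the measured compounds shown here, no step in the set gives a readable gain.

The expectation for compound 4 is thus a step of an at least 1.2-fold lower number from compound 2 to compound 4 (0.09 log units; that floor lies within the scatter), with weak inhibition of growth again the most likely outcome and a fair chance of another limit. The estimate for compound 4 in this assay is 80000 nM, within 25000 nM to 250000 nM.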

Compound 4, concentration for 50% growth inhibition: > 100000 nM
Compound 4: no number, only a limit (the forecaster's own chance of this, stated with the estimate: 55%); middle value at least 1.2-fold (0.09 log units) away from the limit.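

In this assay, compound 4, which carries (pyridin-4-yl)methyl on the nitrogen where compound 2 carries 4-methylphenyl, returns only a limit and no number, so this position has now taken a second ring with one hetero atom without giving a readable gain, and the limit remains the usual result for the series: the limit of > 100000 nM in this assay, at which 3 of the 4 values shown sit.

The steps to compound 4 from compound 1 and from compound 2 cannot be read, as both ends of each are limits. Among the compounds shown here, compound 3 remains the only compound with a number, and the one step that can be read gives an at least 1.9-fold higher number from compound 3 to compound 4 (0.28 log units; that floor lies within the scatter), so even this comparison does not separate 4-chloropyridin-2-yl from (pyridin-4-yl)methyl on this nitrogen.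

The compounds shown leave open whether the chlorine of 4-chloropyridin-2-yl or its ring nitrogen accounts for the number seen with compound 3, as no pair changes one of these alone. On these data alone, it also remains open how an amine, a carboxylic acid or a longer chain in this place would read in this assay.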